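Swapping the amide aryl group of compound 2

The source may report more compounds than this note shows. Statements on the series, on what has been measured and on what is new or still open speak of the compounds shown alone.

In a functional assay on HT-29 cells (Homo sapiens) for cytotoxicity, read by MTT assay, with a stated time of 72 h (on this read-out lower numbers stand for stronger inhibition and higher numbers for weaker inhibition), compound 2 `O=C(CN1CCN(c2nnc(Cc3ccccc3)c3ccccc23)CC1)Nc1ccc(F)c(F)c1` gives 9510 nM as the highest number of three, against compound 3 `O=C(CN1CCN(c2nnc(Cc3ccncc3)c3ccccc23)CC1)Nc1ccc(F)c(F)c1` with 2320 nM and compound 1 `O=C(CN1CCN(c2nnc(Cc3ccncc3)c3ccccc23)CC1)Nc1ccc(Br)cc1` with 1990 nM in the same read-out. Compound 4 `O=C(CN1CCN(c2nnc(Cc3ccccc3)c3ccccc23)CC1)Nc1cccc(Br)c1` differs from compound 2 by 3-bromophenyl in place of 3,4-difluorophenyl on an amide-type nitrogen and so carries 3-bromophenyl in place of 3,4-difluorophenyl on an amide-type nitrogen. The nearest measured change at that place is a 1.2-fold higher number from compound 1 to compound 3 (0.07 log units; within the scatter) and stays within the scatter, although it starts from 4-bromophenyl and was measured with pyridin-4-yl in place of phenyl. The step of a 4.1-fold lower number from compound 2 to compound 3 (0.61 log units; beyond the scatter) lies at another place and does not bear on this swap. No step beyond the scatter is therefore expected in this assay here. The expected change is a 1.2-fold lower number from compound 2 to compound 4 (0.08 log units; within the scatter) and stays within the scatter. For compound 4 the estimate is 8000 nM with an expected range from 3500 nM to 18000 nM as a working figure.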

Compound 4, half-maximal inhibitory concentration: 13400 nM
The estimate for compound 4 lay 1.7-fold (0.22 log units) below the measured number; low and high end bracket the measured number.
By their numbers in this assay, from the lowest: compounds 1 and 3 (each within the scatter of the next); then compounds 2 and 4 (each within the scatter of the next).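

In this assay, 3-bromophenyl in place of 3,4-difluorophenyl on an amide-type nitrogen gives a 1.4-fold higher number from compound 2 to compound 4 (0.15 log units; within the scatter). Exchanging these aryl groups on the amide nitrogen therefore stays within the scatter with phenyl on the chain carbon, as it did for compounds 1 and 3 with pyridin-4-yl. No measurement at hand gives a reason for this result.

Going by these compounds, whether this flat response holds for an aryl group that carries a carboxylic acid or an amine remains open. Also open, on these data alone, is whether pyridin-4-yl would lower the number for the 3-bromophenyl amide as it does for the 3,4-difluorophenyl amide.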